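The source may hold more compounds than are shown below. What is called first, only, known or untested is meant among the compounds shown, and "the series" means these compounds.

Among the compounds with values here, in a functional assay on A2780 cells (Homo sapiens) for inhibition, read by sulforhodamine B assay, with a stated time of 72 h (a higher number here means a weaker inhibitor, a lower number a stronger inhibitor), compound 1 (`O=C(NCc1ccc(S(=O)(=O)N2CCCCC2)cc1)c1cc2cnccc2s1`) gives 1600 nM as the higher of the two numbers so far, which makes it the weaker inhibitor of the pair, and compound 2 (`O=C(NCc1ccc(S(=O)(=O)c2cc(F)cc(F)c2)cc1)c1cnc2nccn2c1`) gives 3 nM as the lower. Compound 3 (`O=C(NCc1ccc(S(=O)(=O)N2CCCCC2)cc1)c1ccc2nc[nH]c2c1`) differs from compound 1 in one place, on a carbonyl carbon, where a group of 9 heavy atoms (7 carbon, 2 nitrogen; one five-membered aromatic ring with 2 hetero atoms, one six-membered aromatic ring of carbon only) in place of a group of 9 heavy atoms (7 carbon, 1 nitrogen, 1 sulfur; one five-membered aromatic ring with 1 hetero atom, one six-membered aromatic ring with 1 hetero atom), on a carbonyl carbon is the change. Within the data shown here, no measured pair shows this change alone, so only a rough expectation is possible: no step beyond the scatter, in either direction. An estimated step (a 1.6-fold lower number from compound 1 to compound 3 (0.20 log units; within the scatter)) of this small size is what is expected. Compound 3 is expected at 1000 nM with 150 nM to 6000 nM as its estimated range.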

Compound 3, half-maximal inhibitory concentration: > 10000 nM
Compound 3: only a limit was reported; the forecaster's own chance of this, stated with the estimate: 15%; middle value at least 10-fold (1.00 log units) away from the limit.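

Within the data shown here, this is the first comparison here between compounds that differ in one place, and it shows that the group on the carbonyl carbon is not freely exchangeable. With the same count of heavy atoms, 1H-benzimidazol-6-yl in place of the group in compound 1 gives an at least 6.2-fold higher number from compound 1 to compound 3 (0.79 log units; beyond the scatter) in this assay. The value for compound 3 is a limit, so the full size of this step stays unknown: the limit of > 10000 nM in this assay, at which 1 of the 3 values shown sits.

Open, from the compounds shown here alone, is how a plain phenyl or pyridyl ring on that carbonyl carbon would compare with compound 1, and what a methyl group on the benzimidazole nitrogen would do to compound 3.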